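Swapping Methyl for Nitro on Compound 2

The source may hold more compounds than are shown below. What is called first, only, known or untested is meant among the compounds shown, and "the series" means these compounds.

In a functional assay on HL-60 cells (Homo sapiens) for inhibition, read by CCK-8 assay, with a stated time of 48 h, tested at 20 uM (a lower number here means less inhibition of growth, a higher number more inhibition of growth at the concentration tested), compound 1 `COc1ccc(Cc2nnc(NC(=O)/C(C#N)=C/c3ccccc3OS(=O)(=O)c3ccc([N+](=O)[O-])cc3)s2)cc1` gives 51%, while compound 2 `Cc1ccc(Cc2nnc(NC(=O)/C(C#N)=C/c3ccccc3OS(=O)(=O)c3ccc(C)cc3)s2)cc1` gives 17%. Compound 2 is therefore the lower of the two measured compounds, and the gap lies beyond the scatter. Compound 3 `Cc1ccc(Cc2nnc(NC(=O)/C(C#N)=C/c3ccccc3OS(=O)(=O)c3ccc([N+](=O)[O-])cc3)s2)cc1` differs from compound 2 in one place, nitro in place of methyl on an aromatic carbon, turning (4-methylphenyl)sulfonyl into (4-nitrophenyl)sulfonyl. Within the data shown here, no step between measured compounds isolates this change, so its size cannot be read directly. Compound 1 also carries (4-nitrophenyl)sulfonyl and reaches 51%, so a rise beyond the scatter is expected in this assay, although compound 1 and compound 2 also differ elsewhere. The expected change is a number 28 percentage points higher from compound 2 to compound 3 (beyond the scatter). For compound 3, the estimated growth inhibition is 45%, within a range of 25% to 65%.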

Compound 3, percent growth inhibition at one concentration: 17%
Compound 3: middle estimate off by 28 percentage points, on the high side; measured number outside the range, below it.
By their numbers in this assay, from the lowest: compounds 2 and 3 (each within the scatter of the next); then compound 1.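

In this assay, nitro in place of methyl on an aromatic carbon, turning (4-methylphenyl)sulfonyl into (4-nitrophenyl)sulfonyl, gives no change at the digits printed from compound 2 to compound 3 (within the scatter), so this change alone does not move growth inhibition in this pair. With (4-nitrophenyl)sulfonyl held constant, the change of methyl in place of methoxy on an aromatic carbon gives a number 34 percentage points lower from compound 1 to compound 3 (beyond the scatter), which ties the higher value of compound 1 to its methoxy rather than to its nitro. Nothing available explains why either step has the size it does.

The compounds shown leave open whether the nitro for methyl change would be just as flat with methoxy present. They also leave open how an amine or a hydroxyl in place of that methoxy, or a carboxylic acid in place of the nitro, would read in this assay.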